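Compound 2 to compound 3: chloro in place of methyl

The compounds below may be only part of what the source reports. "The series", "measured", "known", "first", "only" and "open" are said of these compounds alone.

Among the measured compounds shown here, in a functional assay on the whole organism (strain albino) with Mus musculus as the target, with a stated time of 0.5 h (on this read-out lower numbers stand for an effect already at smaller amounts and higher numbers for an effect only at larger amounts of compound), compound 2 (`CC(=O)N1N=C(Nc2nc3ccc(C)cc3s2)CC1c1ccc(O)cc1`) gives 54.3 umol/kg, the lower of the two numbers measured so far. Compound 1 (`COc1ccc(C2CC(Nc3nc4ccc(Cl)cc4s3)=NN2C(C)=O)cc1O`) gives 132 umol/kg, and this gap lies beyond the usual scatter. The two compounds differ in more than one place, so the gap does not isolate any single change.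

Compound 3 (`CC(=O)N1N=C(Nc2nc3ccc(Cl)cc3s2)CC1c1ccc(O)cc1`) has not yet been measured. It differs from compound 2 by chloro in place of methyl on an aromatic carbon.

For the measured compounds named here, no measured pair shows this change alone, so the expectation is weakly supported. Going by the values given here, the only measured compound with chloro is compound 1, at 132 umol/kg, and it also differs elsewhere. That reading points to a small upward shift at most, not a large one. The expected result is a 1.4-fold higher number from compound 2 to compound 3 (0.14 log units; within the scatter), a modest rise in the number that probably stays within the scatter. For compound 3 the estimated value is 75 umol/kg, with an expected range from 35 umol/kg to 160 umol/kg.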

Compound 3, dose for half-maximal effect: 107 umol/kg
The estimate for compound 3 lay 1.4-fold (0.15 log units) below the measured number; low and high end bracket the measured number.
By their numbers in this assay, from the lowest: compounds 2, 3 and 1 (each within the scatter of the next, the first and the last beyond it).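

In this assay, the change from methyl to chloro on this aromatic carbon can now be read alone, and it gives a 2.0-fold higher number from compound 2 to compound 3 (0.29 log units; within the scatter); a single pair therefore shows no separation between the two groups at this position beyond the scatter. Compound 3 also isolates a second change, 4-hydroxyphenyl in place of 3-hydroxy-4-methoxyphenyl on a saturated ring carbon, which gives a 1.2-fold lower number from compound 1 to compound 3 (0.09 log units; within the scatter), so that change is not resolved from the scatter either. The data shown offer no independent measurement that would explain either step.

From the compounds shown here alone, each change rests on one pair only, so it remains open whether the exchange of methyl for chloro reads the same with 3-hydroxy-4-methoxyphenyl on the saturated ring carbon, or whether the aryl exchange reads the same with methyl on the aromatic carbon. Also open, going by these compounds, is how a methoxy group or an amine on that aromatic carbon, or a carboxylic acid on the phenyl ring, would read on this whole-organism measure.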